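Dropping a Trifluoromethyl Group from a Diaryl Urea

A few compounds are considered here, and "the series" means these few. Any claim that something is new, unique, unknown or untested is made for them only; others in the source may bear on it.

Measured so far in a functional assay on UACC-257 cells (Homo sapiens) for inhibition, read by sulforhodamine B assay, with a stated time of 48 h, tested at 100 uM; on this read-out higher numbers stand for a weaker effect at the one concentration tested and lower numbers for a stronger effect:
- compound 1 `O=C(Nc1cccc(-n2cc(-c3ccncc3)c(-c3cc(O)cc(Cl)c3)n2)c1)Nc1ccc(Cl)c(C(F)(F)F)c1` gives -96%
- compound 2 `O=C(Nc1cccc(-n2cc(-c3ccncc3)c(-c3cc(O)cc(Cl)c3)n2)c1)Nc1ccc(Cl)c(Cl)c1` gives -92%
- compound 3 `COc1cc(Cl)cc(-c2nn(-c3cccc(NC(=O)Nc4cc(C(F)(F)F)cc(C(F)(F)F)c4)c3)cc2-c2ccncc2)c1` gives -88%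

All three compounds share the same core and differ only in the groups on the outer ring of the urea. Compound 3 has the highest number of the three, but its gap to compound 2 and to compound 1 is within the scatter, so the three values cannot be told apart.

Compound 4 `COc1cc(Cl)cc(-c2nn(-c3cccc(NC(=O)Nc4cccc(C(F)(F)F)c4)c3)cc2-c2ccncc2)c1` is compound 3 with one trifluoromethyl group taken away: hydrogen in place of trifluoromethyl on an aromatic carbon. For the measured compounds named here, the only measured step, a number 4 percentage points higher from compound 1 to compound 2 (within the scatter), exchanges a trifluoromethyl for a chloro and stays within the scatter. Going by the values given here, no measured step removes a trifluoromethyl outright, so the evidence for this change is indirect; what is available suggests that small edits at this ring leave the read-out much as it is.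

Compound 4 is therefore expected to give about -85%, with a range from -100% to -60%. The step this estimate implies, a number 3 percentage points higher from compound 3 to compound 4 (within the scatter), is expected to stay within the scatter.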

Compound 4, a percentage reported as activity, at one concentration (the size of the read-out at that concentration, not a potency): -72%
For compound 4 the middle estimate is 13 percentage points below the measured one; measured number inside the range.
By their numbers in this assay, from the lowest: compounds 1, 2 and 3 (each within the scatter of the next); then compound 4.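

In this assay, taking one trifluoromethyl group off the outer ring of the urea gives a number 16 percentage points higher from compound 3 to compound 4 (beyond the scatter) and so, on this read-out, a weaker effect at the one concentration tested; this is the only step shown that stands clear of the scatter. The exchange of trifluoromethyl for chloro between compound 1 and compound 2 left a group in place, whereas here hydrogen enters, bringing no heavy atom, at a carbon meta to a trifluoromethyl group, and the read-out does respond to that edit, though only modestly. Nothing available explains why the number moves with this change.

Still open, on these data alone, is whether an amine or a nitrile at this carbon would keep the number closer to that of compound 3 or move it as far as hydrogen does, and whether removing the remaining trifluoromethyl group as well would shift it further. The compounds shown also leave open whether the same edit would have a similar effect on the core of compound 1, which carries a hydroxyl group where compound 3 carries a methoxy group.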